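Chloro to Nitro on the Amide-Bearing Ring

The source may report more compounds than this note shows. Statements on the series, on what has been measured and on what is new or still open speak of the compounds shown alone.

Compound 1 `COc1cc2c(cc1OC)C(CC(=O)O)CC2` ends its side chain in a hydroxy on a carbonyl carbon; in a functional assay on the whole organism (strain Wistar) for inhibition, with Rattus norvegicus as the target, read by paw edema, with a stated time of 24 h, at a dose of 100 mg/kg (on this read-out higher numbers stand for more inhibition at the one dose given (going by the name of the read-out) and lower numbers for less inhibition), compound 1 gives 26.7%. Replacing that hydroxy with an aromatic amine raises the number: compound 2 `COc1cc2c(cc1OC)C(CC(=O)Nc1ccc(Cl)cc1)CC2` gives 70%, and compound 3 `COc1cc2c(cc1OC)C(CC(=O)Nc1cccc(C)c1)CC2` gives 41.7%. The step of a number 43.3 percentage points higher from compound 1 to compound 2 (beyond the scatter) is the larger of the two, while a number 15 percentage points higher from compound 1 to compound 3 (beyond the scatter) is smaller. Compound 2 stands highest of the three, its nearest neighbour being compound 3, and a number 28.3 percentage points lower from compound 2 to compound 3 (beyond the scatter) shows that the group on the amide nitrogen moves the read-out well beyond the scatter.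

Compound 4 `COc1cc2c(cc1OC)C(CC(=O)Nc1ccc([N+](=O)[O-])cc1)CC2` keeps the amide of compound 2 and alters one group on its aromatic ring: nitro in place of chloro on an aromatic carbon. Among the measured compounds shown here, no measured pair compares chloro with nitro directly. For the measured compounds named here, the only guidance is that a number 43.3 percentage points higher from compound 1 to compound 2 (beyond the scatter) shows the amide itself carries most of the gain, and a number 28.3 percentage points lower from compound 2 to compound 3 (beyond the scatter) shows that changing the aromatic group alters the number to a modest degree. Compound 4 is therefore expected to stay in the upper part of the range seen so far, with an expected step of a number 10 percentage points lower from compound 2 to compound 4 (within the scatter). The estimate for compound 4 in this assay is 60%, expected to lie between 40% and 80%.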

Compound 4, a percentage reported as inhibition, in the whole organism at one dose (the size of the read-out at that dose, not a potency): 43.3%
The estimate for compound 4 lay 16.7 percentage points above the measured number, within the range that was stated.
By their numbers in this assay, from the lowest: compound 1; then compounds 3 and 4 (each within the scatter of the next); then compound 2.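

In this assay, among the compounds shown here, the step of a number 26.7 percentage points lower from compound 2 to compound 4 (beyond the scatter) is the first one in which only the group on this aromatic carbon changes, while the amide and the place on the ring, para to a large group, stay the same. The earlier step from the 4-chlorophenyl to the 3-methylphenyl amide changed both the group and its place on the ring, whereas this one shows that exchanging chloro for nitro at one fixed place is enough to move the read-out beyond the scatter, so the high number of compound 2 does not come from the amide alone, as compound 4 keeps that amide and gives 43.3%. Nothing measured here explains what it is about the nitro group that goes with the lower number.

On these data alone, whether a fluoro or a methoxy group on this same aromatic carbon would stay close to compound 2 or fall closer to compound 4 remains open. A 4-methylphenyl amide would also help, as it would show how a methyl group compares with chloro and nitro at this same place.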